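Cyclohexyl Gives Way to 4-Nitrophenyl in Compound 4

This account rests on a few compounds, and the source may have more. Where it says the series, first, only, none or still open, it means among the compounds named here.

The compounds were tested for cytotoxicity in a functional assay on HeLa cells (Homo sapiens) for cytotoxicity, read by WST assay, with a stated time of 48 h; a higher number here means a weaker inhibitor, a lower number a stronger inhibitor. Compound 1 `O[C@@H](c1ccccc1)[C@H]1CO[C@H](c2ccccc2)[C@@H](C/C=C/C2CCCCC2)C1` gives 6440 nM in this assay, the lowest of the two numbers recorded in the set. Compound 3 `COc1ccc(/C=C/C[C@H]2C[C@@H]([C@@H](O)c3ccc(OC)c(OC)c3)CO[C@@H]2c2ccc(OC)c(OC)c2)cc1` gives 12200 nM in this assay, a value that lies within the usual scatter of the value of compound 1, so the two cannot be placed in order. Within the data shown here, compound 2 `COc1ccc(/C=C/C[C@@H]2C[C@@H]([C@@H](OC)c3ccc(OC)c(OC)c3)CO[C@H]2c2ccc(OC)c(OC)c2)cc1OC` reached only a limit of the assay, > 100000 nM, and no number is known for it; it is the one value that sits at the limit of > 100000 nM in this assay, at which 1 of the 3 values shown sits.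

Compound 4 `O=[N+]([O-])c1ccc(/C=C/C[C@H]2C[C@@H]([C@@H](O)c3ccccc3)CO[C@@H]2c2ccccc2)cc1` has not yet been measured in this assay. It differs from compound 1 in a single place: 4-nitrophenyl in place of cyclohexyl on a double-bonded chain carbon bound to a double-bonded chain carbon. Among the measured compounds shown here, no pair of measured compounds in the set differs by this change alone, so the measured values give no direct guide to its direction. The account therefore expects the step from compound 1 to compound 4 to be modest, a 1.2-fold higher number from compound 1 to compound 4 (0.09 log units; within the scatter), quite possibly not beyond the scatter in either direction. On that basis compound 4 is estimated at 8000 nM in this assay, with a likely range from 2500 nM to 25000 nM.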

Compound 4, half-maximal inhibitory concentration: 12400 nM
Compound 4: the middle estimate sits 1.6-fold (0.19 log units) below what was measured, and the stated range covers the measured number.
By their numbers in this assay, from the lowest: compounds 1, 3 and 4 (each within the scatter of the next). At a limit, above all of these: compound 2.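

Among these compounds, the first one-place comparison at this position comes from this assay: putting 4-nitrophenyl in place of cyclohexyl on a double-bonded chain carbon bound to a double-bonded chain carbon gives a 1.9-fold higher number from compound 1 to compound 4 (0.28 log units; within the scatter). The earlier compounds shown here could not show this, since they differ from one another in more than one place, whereas here the rest of the core stays the same while a non-aromatic ring of carbon gives way to an aromatic one with three more heavy atoms and two hydrogen-bond acceptors, and compound 1 and compound 4 still cannot be placed in order. The measurements shown offer no explanation for this result, and neither a cause nor a property of either group can be drawn from them.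

A single exchange at this position leaves open whether any other group placed there would give a step beyond the scatter, such as an unsubstituted phenyl, a 4-aminophenyl carrying an amine, or a 4-carboxyphenyl carrying a carboxylic acid. It also leaves open whether a longer chain between the core and the terminal ring would change the reading in this assay.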